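The source may report more compounds than this note shows. Statements on the series, on what has been measured and on what is new or still open speak of the compounds shown alone.

Measured in an ADME assay on microsomes from liver (Canis lupus familiaris) for metabolic stability; on this read-out higher numbers stand for a longer-lived compound and lower numbers for a shorter-lived compound:

- Compound 1 `N#Cc1ccc(NCCNc2ncc(-c3ncc[nH]3)c(-c3ccc(Cl)cc3Cl)n2)nc1`: > 0.5 h, a limit
- Compound 2 `Clc1ccc(-c2nc(NCCNc3ccccn3)ncc2-c2ncc[nH]2)c(Cl)c1`: > 0.5 h, a limit
- Compound 3 `Nc1nc(NCCNc2ncc(-c3ncc[nH]3)c(-c3cc(F)ccc3F)n2)ccc1[N+](=O)[O-]`: > 0.5 h, a limit

In this assay compound 3 gives > 0.5 h, which is a limit and not a number. The whole set shares one position, namely (the limit of > 0.5 h in this assay, at which 3 of the 3 values shown sit). No measured number therefore places compound 3 relative to the other two compounds.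

Compound 4 `Nc1nc(NCCNc2ncc(-c3ncc[nH]3)c(-c3ccc(Br)cc3F)n2)ccc1[N+](=O)[O-]` keeps the shared core and chain of compound 3 and exchanges one group, with 4-bromo-2-fluorophenyl in place of 2,5-difluorophenyl on an aromatic carbon.

Among the compounds with values here, only one measured step exists, a step that the two limits leave unreadable from compound 1 to compound 2. It puts hydrogen in place of cyano on an aromatic carbon, a different group from the one exchanged here, and it has no readable size. Within the data shown here, no measurement yet shows what an exchange of this phenyl group does, so no step beyond the usual scatter is expected in this assay, in either direction. The expected change is a step that the limit leaves unreadable from compound 3 to compound 4, an estimate that stays within that scatter. A report of a limit is again the likeliest expected outcome for compound 4. If a number is reported, the estimated half-life for compound 4 is 0.6 h, with an expected range from 0.3 h to 1.2 h.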

Compound 4, half-life: > 0.5 h
Compound 4: no number, only a limit; the forecaster's own chance of this, stated with the estimate: 75%; the middle value lies beyond the limit too.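

In this assay, within the data shown here, compound 4 gives > 0.5 h which is a limit and not a number, so no step from compound 3 to compound 4 can be read. The compounds shown leave open how long any of them actually lasts and what an exchange of the phenyl group does to that, since all share one position: the limit of > 0.5 h in this assay, at which 4 of the 4 values shown sit.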